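The compounds below may be only part of what the source reports. "The series", "measured", "known", "first", "only" and "open" are said of these compounds alone.

Measured in a functional assay on HEK293 cells (Homo sapiens) for inhibition; a higher number here means a weaker inhibitor, a lower number a stronger inhibitor:
- Compound 1 `CCCCCCCCCCCCS(=O)(=O)NCCCNCCCNCCCCNCCCNCCCNS(=O)(=O)CCCCCCCCCCCC`: 10300 nM
- Compound 2 `CCCCCCCCS(=O)(=O)NCCCN(CCCNCCCCNCCCN)CCCNS(=O)(=O)CCCCCCCC`: 669 nM
- Compound 3 `CCCCCCCCCCCCCCCCS(=O)(=O)NCCCN(CCCNCCCCNCCCN)CCCNS(=O)(=O)CCCCCCCCCCCCCCCC`: 4850 nM

Of these three, compound 2 has the lowest number, at 669 nM. Compound 3, at 4850 nM, and compound 1, at 10300 nM, both stand higher, and both gaps lie beyond the usual scatter.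

The next compound to be tested in this assay is compound 4 `CCCCCCCCS(=O)(=O)NCCCN(CCCNCCCNCCCCNCCCN)CCCNS(=O)(=O)CCCCCCCC`. It differs from compound 2 in one place: (4-((3-aminopropyl)amino)butyl)amino in place of ((3-aminopropyl)amino)methyl on a saturated chain carbon, three bonds along the chain from an amine nitrogen. The change falls on a saturated chain carbon, three bonds along the chain from an amine nitrogen, and it extends the amine-bearing arm.

For the measured compounds named here, no measured pair shows this kind of change, so the data offer no direct guide to its size or direction. The starting point is therefore compound 2 at 669 nM, and no step beyond the scatter is expected. The estimated step is a 1.0-fold higher number from compound 2 to compound 4 (0.02 log units; within the scatter). For compound 4 the expected value is 700 nM, with an estimated range of 220 nM to 2200 nM.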

Compound 4, half-maximal inhibitory concentration: 300 nM
The estimate for compound 4 lay 2.3-fold (0.37 log units) above the measured number, within the range that was stated.
By their numbers in this assay, from the lowest: compound 4; then compound 2; then compound 3; then compound 1.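

In this assay, (4-((3-aminopropyl)amino)butyl)amino in place of ((3-aminopropyl)amino)methyl gives a 2.2-fold lower number from compound 2 to compound 4 (0.35 log units; beyond the scatter) on a saturated chain carbon, three bonds along the chain from an amine nitrogen. For the compounds shown here, this is the first comparison in the set that differs in one place, and it shows that this position accepts the longer amine-bearing arm with a modest gain in inhibition rather than a loss. Nothing available bears on why the number falls.

The compounds shown do not separate the added nitrogen from the added chain length, and an all-carbon arm of similar length or a guanidine at the end of the arm would speak to that. From the compounds shown here alone, whether the gain carries over to other sulfonyl chains also stays open.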